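The source may report more compounds than this note shows. Statements on the series, on what has been measured and on what is new or still open speak of the compounds shown alone.

Working notes on the series.

For the measured compounds named here, compound 1, `C[C@H](NC(=O)Nc1cccc(F)c1)c1ccccc1`, and compound 2, `C[C@@H](NC(=O)Nc1cc(F)ccc1F)c1ccccc1`, are the two compounds measured so far in an ADME assay on the whole organism with Oryza sativa as the target, tested at 10 uM; a higher number here means a weaker effect of the compound at the concentration tested, a lower number a stronger effect. In this assay compound 1 gives 88% and compound 2 gives 92%. Compound 2 therefore has the highest of the two numbers, with compound 1 nearest at a value lower by a gap that lies within the usual scatter of this assay; the two values are not distinguished by the data.

Compound 3, `C[C@H](NC(=O)Nc1cc(F)ccc1F)c1ccccc1`, is not yet measured in this assay. It differs from compound 2 as follows: the two compounds have the same atoms and bonds and differ only in configuration as drawn: 1 of 1 stereo elements differ; a stereocentre at a saturated chain carbon is drawn R in compound 2 and S in compound 3. Going by the values given here, the only change is therefore in configuration as drawn.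

Among the compounds with values here, there is no measured step between compounds that differ in one place, so the size of the step from compound 2 to compound 3 cannot be read from the data. The expectation is that the step of a number 4 percentage points lower from compound 2 to compound 3 (within the scatter) stays within the scatter of this assay, in no particular direction. On that basis compound 3 is estimated at 88%, with a range from 75% to 98%.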

Compound 3, a percentage reported as activity, at one concentration (the size of the read-out at that concentration, not a potency): 99%
Compound 3: the middle estimate sits 11 percentage points below what was measured, and the stated range ends below it.
By their numbers in this assay, from the lowest: compounds 1, 2 and 3 (each within the scatter of the next, the first and the last beyond it).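

The change of configuration at the saturated chain carbon reads as a number 7 percentage points higher from compound 2 to compound 3 (within the scatter) in this assay, so this pair does not separate the form drawn R from the form drawn S. That reading applies to the stereocentre alone, with nothing else in the structures to weigh against it: the fact that compounds 2 and 3 differ only in the configuration as drawn. For the compounds shown here, with the configuration drawn alike, fluoro in place of hydrogen on an aromatic carbon reads as a number 11 percentage points higher from compound 1 to compound 3 (beyond the scatter), the first step to lie beyond the scatter, and a modest one, in the direction of a weaker effect at the concentration tested.

Going by these compounds, it remains open whether this fluoro step recurs with the stereocentre drawn R, and whether the two configurations stay within the scatter of each other when chloro, methoxy or a nitrile stands on the aromatic ring in place of fluoro. Also open, on these data alone, is how a longer chain in place of the methyl group at the stereocentre would read in this assay.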